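The source may report more compounds than this note shows. Statements on the series, on what has been measured and on what is new or still open speak of the compounds shown alone.

In a physicochemical assay for lipophilicity, measured as octanol-water partition, at pH 7.4 (a lower number here means a more polar compound, a higher number a more lipophilic compound), compound 3 `Cc1ccc2[nH]c(C(=O)N[C@H]3CN(S(=O)(=O)c4ccccc4)C[C@@H]3C(=O)NC[C@@H]3CCCN3C)cc2c1` gives 2.3, the highest of the three numbers, ahead of compound 1 `Cc1ccc2[nH]c(C(=O)N[C@H]3CN(S(=O)(=O)c4ccnc(C)c4)C[C@@H]3C(=O)NCCN(C)C)cc2c1` with 1.7 and compound 2 `Cc1ccc2[nH]c(C(=O)N[C@H]3CN(S(=O)(=O)c4ccccc4)C[C@@H]3C(=O)NC[C@H]3CCCN3)cc2c1` with 1. Compound 4 `Cc1ccc2[nH]c(C(=O)N[C@H]3CN(S(=O)(=O)c4ccccc4)C[C@@H]3C(=O)NC[C@H]3CCCN3C)cc2c1` has not been measured yet. Its difference from compound 3 is this: the two compounds have the same atoms and bonds and differ only in configuration as drawn: 1 of 3 stereo elements differ; a stereocentre at a saturated ring carbon is drawn S in compound 3 and R in compound 4. Within the data shown here, the only measured step, a number 1.30 log units higher from compound 2 to compound 3 (beyond the scatter), is large, but it records 1-methylpyrrolidin-2-yl in place of pyrrolidin-2-yl, not a change of configuration alone. Among the measured compounds shown here, it therefore bears only weakly here, and no measured pair isolates such a change. With atoms and bonds the same, no shift beyond the scatter is expected, and the estimated step is no change at the digits printed from compound 3 to compound 4 (within the scatter). Compound 4 is expected at 2.3, with an estimated range from 1.9 to 2.7.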

Compound 4, distribution coefficient: 2.3
Compound 4: the middle estimate sits on the measured number at the digits printed, within the range that was stated.
By their numbers in this assay, from the lowest: compound 2; then compound 1; then compounds 3 and 4 (each within the scatter of the next).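

In this assay, among these compounds, drawing the saturated ring carbon R rather than S gives no change at the digits printed from compound 3 to compound 4 (within the scatter), the first reading of configuration alone: the fact that compounds 3 and 4 differ only in the configuration as drawn. Methyl in place of hydrogen on the amine nitrogen in the ring gives a number 1.30 log units higher from compound 2 to compound 4 (beyond the scatter), matching a number 1.30 log units higher from compound 2 to compound 3 (beyond the scatter), so the methyl step reads the same against either drawn configuration.

Going by these compounds, whether the other two stereo elements behave in the same way remains open. So does whether configuration at this carbon still leaves this assay unmoved with ethyl or acetyl on that ring nitrogen.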